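Swapping Fluoro for Methyl on a Monoamine Oxidase B Inhibitor

A few compounds are considered here, and "the series" means these few. Any claim that something is new, unique, unknown or untested is made for them only; others in the source may bear on it.

Measured compounds:
compound 1 `Cc1cc(OCc2cccc(F)c2)ccc1CN1CC[C@H]1C(N)=O`, 258 nM
compound 2 `C#CCN(Cc1ccc(OCc2cccc(F)c2)cc1F)[C@@H](C)C(N)=O`, 93 nM
compound 3 `NC(=O)[C@@H]1CCN1Cc1ccc(OCc2cccc(F)c2)cc1F`, 26 nM

In an assay on Sf9 cells for inhibition of Amine oxidase [flavin-containing] B (Homo sapiens), with stated times of 15 min and 60 min (a lower number here means a stronger inhibitor, a higher number a weaker inhibitor), compound 3 gives 26 nM, the lowest of the three numbers. Compound 1 differs from it only by methyl in place of fluoro on an aromatic carbon, and that one change gave a 9.9-fold higher number from compound 3 to compound 1 (1.00 log units; beyond the scatter). Compound 2, which gives 93 nM, is built on a different core; the difference between the two cores is not broken down here.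

Compound 4 `C#CCN(Cc1ccc(OCc2cccc(F)c2)cc1C)[C@@H](C)C(N)=O` has not yet been measured. It differs from compound 2 by methyl in place of fluoro on an aromatic carbon. For the measured compounds named here, this is the same kind of change as the one from compound 3 to compound 1, though the surroundings are described differently: in compound 1 the methyl sits ortho to a (2-carbamoylazetidin-1-yl)methyl group (8 heavy atoms), while in compound 4 it sits ortho to a large group. Because a 9.9-fold higher number from compound 3 to compound 1 (1.00 log units; beyond the scatter) was a clear weakening, a comparable step is expected here, perhaps somewhat smaller on the different core: a 6.5-fold higher number from compound 2 to compound 4 (0.81 log units; beyond the scatter). Compound 4 is therefore estimated at 600 nM, roughly between 200 nM and 2000 nM.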

Compound 4, half-maximal inhibitory concentration: 320 nM
Compound 4: middle estimate off by 1.9-fold (0.27 log units), on the high side, and the stated range covers the measured number.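

In this assay, methyl in place of fluoro on an aromatic carbon gives a weaker inhibitor on this core too (a 3.4-fold higher number from compound 2 to compound 4 (0.54 log units; beyond the scatter)). For the compounds shown here, with only two cores, this shows that the direction held in both cases, but not what size the step would take on a further core, or which difference between the cores matters. The direction carries over, but the size does not: the same change on two cores in this assay, a 9.9-fold higher number (1.00 log units; beyond the scatter) from compound 3 to compound 1 and a 3.4-fold higher number (0.54 log units; beyond the scatter) from compound 2 to compound 4, 2.9-fold (0.46 log units) apart, beyond the scatter of two such steps

The compounds shown leave open whether other groups on this aromatic carbon, such as chloro, methoxy or an amine, would fit the same picture. They also leave open how either core behaves with a plain hydrogen in that place.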